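Swapping furan for thiophene on a nucleoside core

The source may report more compounds than this note shows. Statements on the series, on what has been measured and on what is new or still open speak of the compounds shown alone.

Compound 1 `C[C@]1(CO)O[C@@H](n2cc(I)c3c(N)ncnc32)[C@H](O)[C@@H]1O` bears iodo on the shared core; in an ADME assay on Huh-7 cells (Homo sapiens) for cytotoxicity (a lower number here means that less compound is tolerated, a higher number that more compound is tolerated), compound 1 gives 27100 nM. Compound 2 `C[C@]1(CO)O[C@@H](n2cc(-c3ccco3)c3c(N)ncnc32)[C@H](O)[C@@H]1O` carries furan-2-yl instead. In this assay compound 2 gives only a limit of the assay, > 44000 nM. The size of an at least 1.6-fold higher number from compound 1 to compound 2 (0.21 log units; that floor lies within the scatter) is known only as a floor because compound 2 sits at the limit of > 44000 nM in this assay, at which 1 of the 2 values shown sits. Compound 3 `C[C@]1(CO)O[C@@H](n2cc(-c3cccs3)c3c(N)ncnc32)[C@H](O)[C@@H]1O` differs from compound 2 by thiophen-2-yl in place of furan-2-yl on an aromatic carbon. Among the compounds with values here, no measured step covers this swap, and the one step seen stayed within the scatter, so no shift beyond it is expected in this assay. Compound 3 is estimated at 50000 nM, between 20000 nM and 120000 nM, an expected step that the limit leaves unreadable from compound 2 to compound 3.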

Compound 3, half-maximal cytotoxic concentration: > 44000 nM
Compound 3 gave a limit, no number; the forecaster's own chance of this, stated with the estimate: 65%; the middle value does not contradict the limit.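

In this assay, the second five-membered aromatic ring at this position, thiophen-2-yl, gives the same kind of result as furan-2-yl: an at least 1.6-fold higher number from compound 1 to compound 3 (0.21 log units; that floor lies within the scatter). Any difference between the furan and thiophen rings cannot be read, because compound 2 and compound 3 both give only a limit, not a number: the limit of > 44000 nM in this assay, at which 2 of the 3 values shown sit.

Going by these compounds, how far the true values of compound 2 and compound 3 lie past that limit stays open. So does whether an amine or a carboxylic acid on this aromatic carbon would give a readable number.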